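Ethyl for Methoxy on a Weak Anilino Compound

A few compounds are considered here, and "the series" means these few. Any claim that something is new, unique, unknown or untested is made for them only; others in the source may bear on it.

The series shares one core, seen in compound 1 `Oc1nc2nonc2nc1Nc1ccc(OC(F)(F)F)cc1Cl`, which in an assay on mitochondria from L6 cells (Rattus norvegicus) for activation, with a stated time of 90 min (a lower number here means that less compound is needed, a higher number that more compound is needed for the effect), gives 1400 nM. Compound 3 `Oc1nc2nonc2nc1Nc1ccc(OCc2ccccc2)cc1` gives 2400 nM in this assay. Compound 2 `COc1cccc(Nc2nc3nonc3nc2O)c1`, with a methoxy group on its aryl ring, gives 75400 nM, the highest of the three numbers; the gap to compound 3 and the wider gap to compound 1 are both beyond the usual scatter, so compound 2 is plainly the least potent of the three in this assay.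

Compound 4 `CCc1cccc(Nc2nc3nonc3nc2O)c1` has not yet been measured. It differs from compound 2 in one place: ethyl in place of methoxy on an aromatic carbon. The new group sits on an aromatic carbon of a six-membered aromatic ring of carbon only, meta to a large group, and is of the same size as the one it replaces.

Among the measured compounds shown here, no measured pair in this set carries the same change, so nothing here fixes its direction. Because compound 2 gives 75400 nM, a weak starting point, the step is estimated to be modest, perhaps a small drop in the number, as a 1.9-fold lower number from compound 2 to compound 4 (0.28 log units; within the scatter). Compound 4 is therefore expected to give about 40000 nM, within a range from 10000 nM to 150000 nM, in this assay.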

Compound 4, half-maximal effective concentration: 25200 nM
The estimate for compound 4 lay 1.6-fold (0.20 log units) above the measured number, and the stated range covers the measured number.
By their numbers in this assay, from the lowest: compounds 1 and 3 (each within the scatter of the next); then compound 4; then compound 2.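

Among the compounds shown here, with the oxygen gone and the heavy-atom count unchanged, the exchange of methoxy for ethyl on this aromatic carbon, meta to a large group, gives the first step in the set that can be read across a single change in this assay: a 3.0-fold lower number from compound 2 to compound 4 (0.48 log units; beyond the scatter). The step is modest, yet it shows that on this anilino compound the hydrogen-bond acceptor of the methoxy group is not needed for the effect, since the compound without it gives the lower number. No measurement in hand bears on why the number moves, so the step stands as an observation on this one pair.

One pair sets no rule for the series, and the compounds shown leave open whether the same exchange would move the number in the same direction on other aryl rings of the set, such as that of compound 1 or compound 3. They also leave open how far this place tolerates change, for instance whether a longer chain such as propyl, an amine or a carboxylic acid on the same carbon would lower the number further or raise it again.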